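A few compounds are considered here, and "the series" means these few. Any claim that something is new, unique, unknown or untested is made for them only; others in the source may bear on it.

Measured so far:
Compound 1 `CCCCCCCCCCCCCCCCCCc1c(O)cc(O)c(C(C)=O)c1O`: 28000 nM
Compound 2 `CC(=O)c1c(O)cc2c(c1O)CCC(C)(C)O2`: > 100000 nM

Among the measured compounds shown here, in a functional assay on HT-29 cells (Homo sapiens) for cytotoxicity, read by XTT assay, with a stated time of 72 h (on this read-out higher numbers stand for weaker inhibition and lower numbers for stronger inhibition), compound 1 gives 28000 nM, the only actual number so far. For compound 2, > 100000 nM is a limit of the assay and not a number. Compound 3 `CCCCCCCC/C=C\CCCCCCCCc1c(O)cc(O)c(C(C)=O)c1O` differs from compound 1 only in its chain: dec-1-en-1-yl in place of decyl on a saturated chain carbon, eight bonds along the chain from an aromatic carbon. This places dec-1-en-1-yl in place of decyl on a saturated chain carbon, eight bonds along the chain from an aromatic carbon. For the measured compounds named here, no measured pair shows this kind of change, so the expectation in this assay starts from compound 1 at 28000 nM, with no step beyond the scatter in either direction. The estimated step runs a 1.1-fold lower number from compound 1 to compound 3 (0.05 log units; within the scatter). Compound 3 is expected at 25000 nM, within a range from 10000 nM to 60000 nM.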

Compound 3, half-maximal inhibitory concentration: > 100000 nM
Compound 3: only a limit was reported (the forecaster's own chance of this, stated with the estimate: 10%); middle value at least 4.0-fold (0.60 log units) from the limit.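

In this assay, dec-1-en-1-yl in place of decyl, on a saturated chain carbon eight bonds along the chain from an aromatic carbon, gives an at least 3.5-fold higher number from compound 1 to compound 3 (0.55 log units; beyond the scatter). This is the only step shown, and it means that one double bond, with the chain's carbon count unchanged, is enough to move the read-out beyond the scatter. Its full size remains unknown, since the value of compound 3 is a limit of the assay and not a number: the limit of > 100000 nM in this assay, at which 2 of the 3 values shown sit.

As far as these compounds go, whether a longer chain, an amine or a carboxylic acid in place of decyl would shift the read-out remains open.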